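The source may hold more compounds than are shown below. What is called first, only, known or untested is meant among the compounds shown, and "the series" means these compounds.

Compound 1 `C#CCn1cc(C(=O)NCCCOC(=O)[C@H]2CCCN2C(=O)OC(C)(C)C)c(=O)c2ccc(Cl)nc21` — in a functional assay on K562 cells (Homo sapiens) for cytotoxicity, read by MTT assay, with a stated time of 72 h (on this read-out lower numbers stand for stronger inhibition and higher numbers for weaker inhibition), compound 1 gives > 10000 nM, a limit of the assay.
Compound 2 `C#CCn1cc(C(=O)NCCCOC(=O)[C@H](C)NC(=O)OC(C)(C)C)c(=O)c2ccc(Cl)nc21` — in this assay compound 2 gives > 10000 nM, a limit of the assay.
Compound 3 `C#CCn1cc(C(=O)N[C@@H](C)CCOC(=O)[C@H]2CCCN2C(=O)OC(C)(C)C)c(=O)c2ccc(Cl)nc21` — in this assay compound 3 gives > 10000 nM, a limit of the assay.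

Compound 3 therefore stands at the limit of > 10000 nM in this assay, at which 3 of the 3 values shown sit; no number separates it from compound 1 or compound 2. Compound 4 `C#CCn1cc(C(=O)N[C@@H](C)CCOC(=O)[C@H](C)NC(=O)OC(C)(C)C)c(=O)c2ccc(Cl)nc21` differs from compound 3 by 1-((tert-butoxycarbonyl)amino)ethyl in place of 1-(tert-butoxycarbonyl)pyrrolidin-2-yl on a carbonyl carbon. The same exchange has been made once before on the shared core, from compound 1 to compound 2, where it gave a step that the two limits leave unreadable from compound 1 to compound 2. The methyl that compound 3 and compound 4 carry, introduced from compound 1 to compound 3, gave a step that the two limits leave unreadable from compound 1 to compound 3. Neither step yields a readable size or direction, so no step beyond the scatter can be expected from this exchange, and compound 4 is expected to remain at the limit as well. The estimated step is a step that the limit leaves unreadable from compound 3 to compound 4. For compound 4 in this assay the estimate is 15000 nM, with a range from 5000 nM to 50000 nM.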

Compound 4, half-maximal inhibitory concentration: > 10000 nM
Compound 4 ended at the assay's limit (the forecaster's own chance of this, stated with the estimate: 85%); the middle value is on the limit's open side.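

Compound 4 joins compound 1, compound 2 and compound 3 at the limit, so no step from compound 2 or compound 3 to compound 4 can be read: the limit of > 10000 nM in this assay, at which 4 of the 4 values shown sit.

The compounds shown leave open whether either the 1-((tert-butoxycarbonyl)amino)ethyl exchange or the methyl changes the read-out in this assay at all.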